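Swapping a pyrazole for a methylpyridine on a shared core

The source may hold more compounds than are shown below. What is called first, only, known or untested is meant among the compounds shown, and "the series" means these compounds.

Of the compounds shown here, three have been measured in a physicochemical assay for lipophilicity, using the shake flask method, in phosphate buffer, measured as octanol-water partition, with a stated time of 30 min, at pH 7.4; a lower number here means a more polar compound, a higher number a more lipophilic compound. Compound 1, `Cn1cc(-c2cnc(NCc3c(F)ccc4c3CCO4)c3cn[nH]c(=O)c23)cn1`, gives 2.7. Compound 2, `O=C(Nc1cnc(NCc2c(F)ccc3c2CCO3)n2cnnc12)c1ccccc1`, gives 3, within the scatter of compound 1. Compound 3, `O=C1CC2(CC2)CN1c1cnc(NCc2c(F)ccc3c2CCO3)n2cnnc12`, gives 1.9, the lowest of the three. Among the compounds with values here, the only single-point step so far, a number 1.10 log units lower from compound 2 to compound 3 (beyond the scatter), concerns a different part of the molecule and does not directly inform the change at hand. Compound 4, `Cc1ncccc1-c1cnc(NCc2c(F)ccc3c2CCO3)c2cn[nH]c(=O)c12`, differs from compound 1 by 2-methylpyridin-3-yl in place of 1-methyl-1H-pyrazol-4-yl on an aromatic carbon. The entering group carries one more heavy atom and one fewer hydrogen-bond acceptor than the leaving group, so a modest rise in this assay is expected, a number 0.50 log units higher from compound 1 to compound 4 (beyond the scatter). Compound 4 is therefore estimated at 3.2, between 2.7 and 3.7.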

Compound 4, distribution coefficient: 3
Compound 4: middle estimate off by 0.20 log units, on the high side, within the range that was stated.
By their numbers in this assay, from the lowest: compound 3; then compounds 1, 2 and 4 (each within the scatter of the next).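

In this assay, placing 2-methylpyridin-3-yl in place of 1-methyl-1H-pyrazol-4-yl on this aromatic carbon of the shared core gives a number 0.30 log units higher from compound 1 to compound 4 (within the scatter). At this position, then, a five-membered aromatic ring can give way to a six-membered one with no change that stands clear of the scatter. No supporting measurement is available to explain this result. The compounds shown leave open how a carboxylic acid or an amine on this carbon would read in this assay. They also leave open whether the methyl group of 2-methylpyridin-3-yl matters to this step.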